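The source may report more compounds than this note shows. Statements on the series, on what has been measured and on what is new or still open speak of the compounds shown alone.

Working notes on the series. Three compounds carry a number in a functional assay on T-24 cells (Homo sapiens) for cytotoxicity, read by MTT assay, with a stated time of 2 days; a higher number here means a weaker inhibitor, a lower number a stronger inhibitor. Compound 1 `O/N=C1/C(c2c[nH]c3ccc(OCc4ccccc4)cc23)=Nc2ccc(OCc3ccccc3)cc21` gives 11800 nM in this assay. Compound 2 `Fc1ccc2c(c1)/C(=N\OCc1ccccc1)C(c1c[nH]c3ccc(F)cc13)=N2` gives 12500 nM in this assay. Compound 3 `Cc1ccc(CO/N=C2/C(c3c[nH]c4ccccc34)=Nc3ccccc32)cc1` gives 23500 nM in this assay. Compound 3 sits at the top of the three numbers, but its gaps to compound 2 and to compound 1 are both within the scatter, so the three cannot be ranked against one another on what is shown.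

Compound 4 `Fc1ccc(CO/N=C2/C(c3c[nH]c4ccccc34)=Nc3ccccc32)c(Cl)c1` has not yet been measured in this assay. It differs from compound 3 in one place: 2-chloro-4-fluorophenyl in place of 4-methylphenyl on a saturated chain carbon bound to an oxygen on an unsaturated carbon. Within the data shown here, no pair of measured compounds isolates this kind of change, so nothing in the numbers says which way it should move. With the three measured numbers lying close together across different substituents, the expectation is that compound 4 stays within the same band, and the step from compound 3 to compound 4 is expected to be a 1.2-fold lower number from compound 3 to compound 4 (0.07 log units; within the scatter), within the scatter. Compound 4 is thus estimated at 20000 nM in this assay, in a range from 8000 nM to 50000 nM.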

Compound 4, half-maximal inhibitory concentration: 20000 nM
Beside the measured number, compound 4's estimate shows no gap at the digits printed; low and high end bracket the measured number.
By their numbers in this assay, from the lowest: compounds 1, 2, 4 and 3 (each within the scatter of the next).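

Among these compounds, the step of a 1.2-fold lower number from compound 3 to compound 4 (0.07 log units; within the scatter) in this assay is the first that isolates a change in one place. On a saturated chain carbon bound to an oxygen on an unsaturated carbon, 2-chloro-4-fluorophenyl therefore stands in for 4-methylphenyl with no difference that can be read beyond the scatter. This single pair gives no sign that the number depends on which of these two substituted phenyl groups is present, and no measured property bears on the result.

Still open, from the compounds shown here alone, is whether an amine or a carboxylic acid on this phenyl ring, or a longer chain in place of the benzyl link, would move the number beyond the scatter. Among the compounds shown here, this change is also read on only one core, so its behaviour on the cores of compound 1 and compound 2 remains unknown.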